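A few compounds are considered here, and "the series" means these few. Any claim that something is new, unique, unknown or untested is made for them only; others in the source may bear on it.

Among the measured compounds shown here, compound 2 `O=C(CSc1nc2ccc(NC(=O)c3ccccc3)cc2s1)NCc1ccccc1` gives 34200 nM in a functional assay on HepG2 cells (Homo sapiens) for cytotoxicity, read by MTT assay, with a stated time of 48 h (on this read-out higher numbers stand for weaker inhibition and lower numbers for stronger inhibition), and stands highest of the three numbers measured so far. Its nearest neighbour is compound 1 `O=C(CSc1nc2ccc(NC(=O)c3ccccc3)cc2s1)NCc1ccc(Cl)cc1`, which gives 30100 nM; the step of a 1.1-fold higher number from compound 1 to compound 2 (0.06 log units; within the scatter) lies within the scatter. Compound 3 `COc1ccc(CNC(=O)CSc2nc3ccc(NC(=O)c4ccccc4)cc3s2)cc1` gives 12700 nM; the steps of a 2.4-fold lower number from compound 1 to compound 3 (0.37 log units; beyond the scatter) and a 2.7-fold lower number from compound 2 to compound 3 (0.43 log units; beyond the scatter) are modest but beyond the scatter. Compound 4 `O=C(CSc1nc2ccc(NC(=O)c3ccc(Cl)cc3)cc2s1)NCc1ccccc1` is not yet measured. It differs from compound 2 by chloro in place of hydrogen on an aromatic carbon. For the measured compounds named here, the only measured step that bears on this change is the one from compound 1 to compound 2, where chloro in place of hydrogen on a different ring left this assay unchanged within the scatter, so no step beyond the scatter is expected. Compound 4 is estimated at 30000 nM (range 14000 nM to 65000 nM), a step of a 1.1-fold lower number from compound 2 to compound 4 (0.06 log units; within the scatter) from compound 2 expected.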

Compound 4, half-maximal inhibitory concentration: 25400 nM
Beside the measured number, compound 4's estimate is 1.2-fold (0.07 log units) above it; low and high end bracket the measured number.
By their numbers in this assay, from the lowest: compounds 3, 4, 1 and 2 (each within the scatter of the next, the first and the last beyond it).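

In this assay, chloro in place of hydrogen on the benzoyl ring, para to a large group, gives a 1.3-fold lower number from compound 2 to compound 4 (0.13 log units; within the scatter) and so stays within the scatter. Chloro on the other terminal ring behaved alike, with a 1.1-fold higher number from compound 1 to compound 2 (0.06 log units; within the scatter), so in these two pairs neither ring shows a change beyond the scatter with chloro. Nothing available explains either step.

Methoxy on the other terminal ring gives a 2.7-fold lower number from compound 2 to compound 3 (0.43 log units; beyond the scatter), but its effect on the benzoyl ring remains open. So does the effect of an amine or a carboxylic acid at this position.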